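Methyl on the Sulfonyl Ring: Two Cinnamoyl Sulfonamide Pairs

A few compounds are considered here, and "the series" means these few. Any claim that something is new, unique, unknown or untested is made for them only; others in the source may bear on it.

Compound 1 `CN(C)c1ccc(/C=C/C(=O)NS(=O)(=O)c2ccccc2)cc1`: 2.3 ug/mL
Compound 2 `Cc1ccc(S(=O)(=O)NC(=O)/C=C/c2ccc(N(C)C)cc2)cc1`: 4.3 ug/mL
Compound 3 `O=C(/C=C/c1ccccc1[N+](=O)[O-])NS(=O)(=O)c1ccccc1`: 6 ug/mL

Three cinnamoyl sulfonamides were tested in a functional assay on B16-F10 cells (Mus musculus) for antiproliferative activity, read by ELISA and MTT assay, with a stated time of 48 h; a higher number here means a weaker inhibitor, a lower number a stronger inhibitor. Compound 1 gives 2.3 ug/mL in this assay, compound 2 gives 4.3 ug/mL, and compound 3 gives 6 ug/mL. Between compound 1 and compound 2 the change is methyl in place of hydrogen on an aromatic carbon, and the step measured in this assay was a 1.9-fold higher number from compound 1 to compound 2 (0.27 log units; within the scatter). The difference between the core of compound 1 and the core of compound 3 is not broken down here.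

Compound 4 `Cc1ccc(S(=O)(=O)NC(=O)/C=C/c2ccccc2[N+](=O)[O-])cc1` is not yet measured. It differs from compound 3 by methyl in place of hydrogen on an aromatic carbon, the same change as between compound 1 and compound 2, at a place described in the same words. On the strength of the earlier step, a 1.9-fold higher number from compound 1 to compound 2 (0.27 log units; within the scatter), a step of similar size, a 1.5-fold higher number from compound 3 to compound 4 (0.18 log units; within the scatter), is expected from compound 3 to compound 4 in this assay. The value of compound 4 is therefore estimated at 9 ug/mL, with a range from 4 ug/mL to 20 ug/mL; this rests on one prior example only and carries the scatter of that single step.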

Compound 4, half-maximal inhibitory concentration: 10.3 ug/mL
Estimate against measurement, compound 4: 1.1-fold (0.06 log units) below, and the stated range covers the measured number.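

On the core of compound 3, the change from phenyl to 4-methylphenyl gives in this assay a 1.7-fold higher number from compound 3 to compound 4 (0.23 log units; within the scatter) and so reads much as it did on the core of compound 1: the same change on two cores in this assay, a 1.9-fold higher number (0.27 log units; within the scatter) from compound 1 to compound 2 and a 1.7-fold higher number (0.23 log units; within the scatter) from compound 3 to compound 4, 1.1-fold (0.04 log units) apart, within the scatter of two such steps. The change therefore carries across these two cores with a step of matching size, and the number moves the same way in both pairs. Each step on its own lies within the scatter, however, so the pairs do not establish that the methyl alters the number at all, and two cores cannot show how the change would behave on any other core in the series.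

The compounds shown hold only hydrogen or methyl at this place on the sulfonyl ring, so a chlorine, a methoxy group or a longer chain such as ethyl remains open there. The cinnamoyl end carries only the dimethylamino and nitro groups, so whether the step holds with a carboxylic acid on that end is open too.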